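Working notes: expected value of compound 4 from compounds 1 to 3

The source may hold more compounds than are shown below. What is called first, only, known or untested is meant among the compounds shown, and "the series" means these compounds.

Measured values in a functional assay on A549 cells (Homo sapiens) for inhibition, read by MTT assay, with a stated time of 72 h; a higher number here means a weaker inhibitor, a lower number a stronger inhibitor:
compound 1 `COc1ccccc1-n1c(-c2coc3cc(C)c(Cl)cc3c2=O)nc(-c2ccccc2)c1-c1ccccc1`: 12500 nM
compound 2 `Cc1cc2occ(-c3nc(-c4ccccc4)c(-c4ccccc4)n3-c3cccc(Cl)c3)c(=O)c2cc1Cl`: 25000 nM
compound 3 `COc1cccc(-n2c(-c3coc4cc(C)c(Cl)cc4c3=O)nc(-c3ccccc3)c2-c2ccccc2)c1`: 6250 nM

Compound 3 has the lowest number of the three, but compound 1 lies within the scatter of it (a 2.0-fold lower number from compound 1 to compound 3 (0.30 log units; within the scatter)); only compound 2 stands clearly apart (a 4.0-fold lower number from compound 2 to compound 3 (0.60 log units; beyond the scatter)). Compound 4 `Cc1cccc(-n2c(-c3coc4cc(C)c(Cl)cc4c3=O)nc(-c3ccccc3)c2-c2ccccc2)c1` differs from compound 3 by methyl in place of methoxy on an aromatic carbon. Among the compounds with values here, no measured step swaps methoxy for methyl. Within the data shown here, the only guide at the same place is the modest step of a 4.0-fold lower number from compound 2 to compound 3 (0.60 log units; beyond the scatter), which shows that the group on this aromatic carbon can shift the number. With methyl entering, a small rise in the number, within the scatter, is expected: a 1.4-fold higher number from compound 3 to compound 4 (0.16 log units; within the scatter). Compound 4 is therefore estimated at 9000 nM, in the range 3500 nM to 25000 nM.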

Compound 4, half-maximal inhibitory concentration: 12500 nM
Estimate against measurement, compound 4: 1.4-fold (0.14 log units) below; the range from low to high includes it.
By their numbers in this assay, from the lowest: compounds 3, 1, 4 and 2 (each within the scatter of the next, the first and the last beyond it).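

Methyl in place of methoxy gives a 2.0-fold higher number from compound 3 to compound 4 (0.30 log units; within the scatter) in this assay and methyl in place of chloro gives a 2.0-fold lower number from compound 2 to compound 4 (0.30 log units; within the scatter), so at this aromatic carbon methyl lies within the scatter of both groups, even though compound 2 and compound 3 stand apart from each other. Across the two aromatic positions, 3-methylphenyl in place of 2-methoxyphenyl gives no change at the digits printed from compound 1 to compound 4 (within the scatter). Nothing available explains these values. Still open, on these data alone, is whether an amine or a carboxylic acid on this aromatic carbon would give a step beyond the scatter from compound 4.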